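The source may hold more compounds than are shown below. What is called first, only, known or untested is meant among the compounds shown, and "the series" means these compounds.

Measured in a functional assay on DU-145 cells (Homo sapiens) for antiproliferative activity, read by sulforhodamine B assay, with a stated time of 3 days; a higher number here means a weaker inhibitor of growth, a lower number a stronger inhibitor of growth:
- Compound 1 `CN1CCC(C(=O)Nc2cccc(Nc3ncc(F)c(Nc4ccc(F)cc4)n3)c2)CC1`: 1150 nM
- Compound 2 `O=C(Nc1cccc(Nc2ncc(F)c(Nc3ccc(F)cc3)n2)c1)c1ccccc1`: > 10000 nM

Compound 1 has a number in this assay. Compound 2 has none, only a limit of the assay, > 10000 nM.

Compound 3 `CN(C)CC(=O)Nc1cccc(Nc2ncc(F)c(Nc3ccc(F)cc3)n2)c1` differs from compound 2 in one place, with (dimethylamino)methyl in place of phenyl on a carbonyl carbon. Within the data shown here, one measured step bears on this change, an at least 8.6-fold higher number from compound 1 to compound 2 (0.93 log units; beyond the scatter), in which phenyl stands in place of 1-methylpiperidin-4-yl at the same carbonyl carbon. Going from compound 2 to compound 3 removes that phenyl again, though the group that enters is not the one found in compound 1. The parallel is therefore only partial, and compound 3 may still end at the limit. Among the measured compounds shown here, a lower number is expected in this assay, of a size that the single step can only roughly suggest. The expected step is an at least 3.3-fold lower number from compound 2 to compound 3 (0.52 log units; beyond the scatter). Compound 3 is estimated at 3000 nM, with an expected range of 800 nM to 10000 nM.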

Compound 3, concentration for 50% growth inhibition: 1210 nM
The estimate for compound 3 lay 2.5-fold (0.39 log units) above the measured number; low and high end bracket the measured number.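

In this assay, among these compounds, putting (dimethylamino)methyl in place of phenyl on the carbonyl carbon gives an at least 8.2-fold lower number from compound 2 to compound 3 (0.91 log units; beyond the scatter), so the drop seen with phenyl is reversed by a group other than the one in compound 1. The 1-methylpiperidin-4-yl ring is therefore not needed to keep this level of growth inhibition: exchanging it for the ring-free (dimethylamino)methyl gives a 1.1-fold higher number from compound 1 to compound 3 (0.02 log units; within the scatter). Among these three compounds, the two groups that contain nitrogen give measured numbers, whereas the carbon-only phenyl of compound 2 gives only a limit, so the recovery from that compound can be read only as a minimum: the limit of > 10000 nM in this assay, at which 1 of the 3 values shown sits.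

The compounds shown do not separate the presence of the amine nitrogen from the loss of the phenyl ring, a question that a carbon-only group such as cyclohexyl or isopropyl on the same carbonyl carbon would address. Also open, from the compounds shown here alone, is how the number would respond to a longer chain between the carbonyl and the dimethylamino group, or to a carboxylic acid in place of that amine.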